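Amide-nitrogen truncation in a thiophene carboxamide series

A few compounds are considered here, and "the series" means these few. Any claim that something is new, unique, unknown or untested is made for them only; others in the source may bear on it.

Compound 1 `CC1(C)CNC(=O)c2sc(Nc3ccc(I)cc3F)c(C(=O)N[C@@H]3CCNC3)c2C1` gives 54 nM in a functional assay on HT-29 cells (Homo sapiens) for antiproliferative activity (a lower number here means a stronger inhibitor, a higher number a weaker inhibitor), and holds the lowest number of the two measured; compound 2 `CC1(C)CNC(=O)c2sc(Nc3ccc(I)cc3Cl)c(C(=O)NOC[C@H](O)CO)c2C1` gives 896 nM in this assay, a gap beyond the usual scatter, though the two differ in more than one place. Compound 3 `CC1(C)CNC(=O)c2sc(Nc3ccc(I)cc3F)c(C(N)=O)c2C1` changes compound 1 in one way: hydrogen in place of pyrrolidin-3-yl on an amide-type nitrogen. The pyrrolidin-3-yl group leaves and hydrogen enters on the amide-type nitrogen. Among the measured compounds shown here, no measured pair isolates this change, so the expectation for compound 3 is a moderate weakening, a step of a 3.0-fold higher number from compound 1 to compound 3 (0.47 log units; beyond the scatter) in this assay. Compound 3 is estimated at 160 nM, within 45 nM to 600 nM.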

Compound 3, half-maximal inhibitory concentration: 158 nM
Estimate against measurement, compound 3: 1.0-fold (0.01 log units) above; the range from low to high includes it.
By their numbers in this assay, from the lowest: compound 1; then compound 3; then compound 2.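

In this assay the step is a 2.9-fold higher number from compound 1 to compound 3 (0.47 log units; beyond the scatter) when hydrogen replaces pyrrolidin-3-yl on the amide-type nitrogen, a modest change that lies beyond the scatter. The pyrrolidin-3-yl group is therefore not needed for activity in this series: the plain carbamoyl of compound 3 keeps it, and the ring adds only a modest gain. Nothing available explains this step.

On these data alone, whether that gain belongs to the ring or to its amine remains open. A cyclopentyl group or a short aminoethyl chain on the same nitrogen would separate the two.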